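From 4-azidophenyl to 3-hydroxyphenyl: how large a step?

The source may report more compounds than this note shows. Statements on the series, on what has been measured and on what is new or still open speak of the compounds shown alone.

Compound 1 `COc1cc(N2C(=O)[C@@H](Oc3ccccc3)[C@H]2c2cccc([N+](=O)[O-])c2)cc(OC)c1OC` gives 30000 nM in the test
Compound 2 `COc1cc(N2C(=O)[C@@H](Oc3ccccc3)[C@H]2c2ccc(SC)cc2)cc(OC)c1OC` gives 7700 nM in the test
Compound 3 `COc1cc(N2C(=O)[C@@H](Oc3ccccc3)[C@H]2c2ccc(N=[N+]=[N-])cc2)cc(OC)c1OC` gives 23000 nM in the test

The test behind these numbers is a functional assay on MCF7 cells (Homo sapiens) for antiproliferative activity, read by MTT assay, with stated times of 24 h and 72 h (a lower number here means a stronger inhibitor, a higher number a weaker inhibitor), and it shows a 1.3-fold lower number from compound 1 to compound 3 (0.12 log units; within the scatter), so compound 3 sits level with compound 1. It also shows a 3.0-fold higher number from compound 2 to compound 3 (0.48 log units; beyond the scatter), which leaves compound 2 as the strongest inhibitor of the three.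

The next molecule is compound 4 `COc1cc(N2C(=O)[C@@H](Oc3ccccc3)[C@H]2c2cccc(O)c2)cc(OC)c1OC`, which keeps the shared core. The change, (3-hydroxyphenyl in place of 4-azidophenyl on a saturated ring carbon), is 3-hydroxyphenyl in place of 4-azidophenyl on a saturated ring carbon. Among the measured compounds shown here, no measured compound has a hydroxyl on this aromatic ring, so no step shows this swap directly. The closest guide is what other swaps on the same carbon have done. The largest of them, a 3.9-fold lower number from compound 1 to compound 2 (0.59 log units; beyond the scatter), is only modest, and the other, a 1.3-fold lower number from compound 1 to compound 3 (0.12 log units; within the scatter), stays within the scatter. A small change is therefore expected in this assay, with a slight lean towards a lower number. The expected result is a 1.6-fold lower number from compound 3 to compound 4 (0.22 log units; within the scatter) and thus no clear step beyond the scatter. The estimate for compound 4 is 14000 nM with an expected range from 4000 nM to 40000 nM for repeat measurements.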

Compound 4, half-maximal inhibitory concentration: 54000 nM
For compound 4 the middle estimate is 3.9-fold (0.59 log units) below the measured one; measured number outside the range, above it.
By their numbers in this assay, from the lowest: compound 2; then compounds 3, 1 and 4 (each within the scatter of the next, the first and the last beyond it).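

In this assay, among the compounds shown here, a hydroxyl on this aromatic ring appears for the first time and brings no gain: the swap from 4-azidophenyl gives a 2.3-fold higher number from compound 3 to compound 4 (0.37 log units; beyond the scatter) and stands as a modest loss. Measured against the 4-(methylsulfanyl)phenyl group, the same 3-hydroxyphenyl group gives a 7.0-fold higher number from compound 2 to compound 4 (0.85 log units; beyond the scatter) and so widens the spread of numbers seen at this saturated ring carbon, with compound 2 still the strongest inhibitor of the four. Hydroxy in place of nitro on the aromatic carbon gives a 1.8-fold higher number from compound 1 to compound 4 (0.26 log units; within the scatter) and leaves compound 1 and compound 4 level, so this assay does not separate these two groups at this ring position.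

Nothing available explains why the numbers move as they do. The two compounds with a group at the 4-position of this ring also differ in that group from the two with one at the 3-position, so a 4-hydroxyphenyl compound would show whether moving the hydroxyl matters, and an amine or a methoxy group on the same ring would show whether 3-hydroxyphenyl and 3-nitrophenyl being level extends to other groups.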